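The compounds below may be only part of what the source reports. "The series", "measured", "known", "first", "only" and "open" are said of these compounds alone.

Measured so far:
compound 1 `CC(C)(C)NC(=O)N1CC1C#N` — 132000 nM
compound 2 `N#CC1CN1C(=O)Nc1ccc(S(N)(=O)=O)cc1` — > 38000 nM

For the measured compounds named here, in a functional assay on L1210 cells (Mus musculus) for inhibition, read by MTT assay (a higher number here means a weaker inhibitor, a lower number a stronger inhibitor), compound 1 gives 132000 nM, the only real number in the set. In this assay compound 2 is reported only as a limit, > 38000 nM (the limit of > 38000 nM in this assay, at which 1 of the 2 values shown sits). Compound 1 is therefore the sole fixed point. Compound 3 `CNC(=O)N1CC1C#N` is not yet measured; it differs from compound 1 by methyl in place of tert-butyl on an amide-type nitrogen. Going by the values given here, no measured pair shows this change, so no step beyond the scatter is expected in either direction. Compound 3 is expected to give 150000 nM, between 40000 nM and 500000 nM, a step of a 1.1-fold higher number from compound 1 to compound 3 (0.06 log units; within the scatter).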

Compound 3, half-maximal inhibitory concentration: 8700 nM
Beside the measured number, compound 3's estimate is 17-fold (1.24 log units) above it; the whole stated range lies above it.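

In this assay, the group on the amide-type nitrogen clearly affects the read-out: methyl in place of tert-butyl gives a 15-fold lower number from compound 1 to compound 3 (1.18 log units; beyond the scatter). For the compounds shown here, this is the only readable step, and it links the group with 1 heavy atom, rather than the group with 4, to the stronger inhibitor in this single pair. Nothing shown gives a cause for this step.

A single pair sets no trend with chain size. On these data alone, whether ethyl, isopropyl or a longer chain bearing an amine or a carboxylic acid on this nitrogen would follow compound 3 or compound 1 remains open.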